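Compound 3: 4-methoxyphenoxy in place of 4-methoxyphenyl

The compounds below may be only part of what the source reports. "The series", "measured", "known", "first", "only" and "open" are said of these compounds alone.

Compound 1 `CCc1ccccc1N(Cc1nnc(Cc2ccc(OC)cc2)o1)S(=O)(=O)c1ccc(C)cc1` gives 631 nM in a functional assay on CHO cells for antagonist activity at prostaglandin E2 receptor EP1 subtype (Homo sapiens), read by FLIPR and calcium flux; on this read-out lower numbers stand for stronger inhibition and higher numbers for weaker inhibition. Among the compounds with values here, it stands highest of the two numbers measured so far; the nearest is compound 2 `COc1ccc(Cc2nnc(CN(c3cccc(C(F)(F)F)c3C)S(=O)(=O)c3ccc(C)cc3)o2)cc1`, which in this assay gives 398 nM, and the step of a 1.6-fold lower number from compound 1 to compound 2 (0.20 log units; within the scatter) lies within the scatter. Compound 3 `CCc1ccccc1N(Cc1nnc(COc2ccc(OC)cc2)o1)S(=O)(=O)c1ccc(C)cc1` has not yet been measured. It differs from compound 1 in one place: 4-methoxyphenoxy in place of 4-methoxyphenyl on a saturated chain carbon bound to an aromatic carbon. Within the data shown here, the only measured step, a 1.6-fold lower number from compound 1 to compound 2 (0.20 log units; within the scatter), alters the group on the sulfonamide nitrogen and leaves the 4-methoxybenzyl arm untouched, so it does not bear on the present change; no measured pair varies this arm at all. The expectation therefore rests on compound 1 alone. Compound 3 is expected to show no step beyond the scatter: a 1.1-fold higher number from compound 1 to compound 3 (0.05 log units; within the scatter). Compound 3 is estimated at 700 nM, with a range from 250 nM to 2000 nM that is wide for want of any comparable step.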

Compound 3, inhibition constant: 126 nM
Beside the measured number, compound 3's estimate is 5.6-fold (0.74 log units) above it, and the stated range ends above it.
By their numbers in this assay, from the lowest: compound 3; then compounds 2 and 1 (each within the scatter of the next).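

Working notes on the series: the 4-methoxybenzyl arm, held constant in the earlier pair, responds to change in this assay and shows a 5.0-fold lower number from compound 1 to compound 3 (0.70 log units; beyond the scatter) for the swap to (4-methoxyphenoxy)methyl. Within the data shown here, the step is modest, but it is the first beyond the scatter, whereas a 1.6-fold lower number from compound 1 to compound 2 (0.20 log units; within the scatter) on the sulfonamide nitrogen stays within it. This single substitution on the saturated chain carbon therefore gives the series its first clear difference in inhibition, with the 4-methoxyphenyl end retained and an oxygen entering the link. Nothing measured here accounts for the step.

From the compounds shown here alone, it remains open whether the same swap holds with the 2-methyl-3-(trifluoromethyl)phenyl group of compound 2 on the sulfonamide nitrogen. Going by these compounds, it is also open how a sulfur atom, an amine nitrogen or a longer chain in place of the oxygen link would read out.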